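The source may hold more compounds than are shown below. What is called first, only, known or untested is meant among the compounds shown, and "the series" means these compounds.

Measured compounds:
compound 1, `C=CCN(CC)S(=O)(=O)NC(=O)Nc1c(C(C)C)cccc1C(C)C`, 2100 nM
compound 2, `C=CCN(CC=C)S(=O)(=O)NC(=O)Nc1c(C(C)C)cccc1C(C)C`, 2700 nM
compound 3, `CCCCN(CC)S(=O)(=O)NC(=O)Nc1c(C(C)C)cccc1C(C)C`, 1200 nM

In an assay on liver for inhibition of sterol O-acyltransferase 1 (Rattus norvegicus), using microsomes (a higher number here means a weaker inhibitor, a lower number a stronger inhibitor), compound 3 holds the lowest of the three numbers; the step from compound 1 to compound 3 is a 1.8-fold lower number from compound 1 to compound 3 (0.24 log units; within the scatter), and the step from compound 2 to compound 3 is a 2.3-fold lower number from compound 2 to compound 3 (0.35 log units; beyond the scatter). Compound 4, `CCCCCCNS(=O)(=O)NC(=O)Nc1c(C(C)C)cccc1C(C)C`, differs from compound 3 in one place: hexylamino in place of butyl(ethyl)amino on a sulfonyl sulfur. All three measured steps also rework the groups on the sulfonyl sulfur, and they stayed small: a 1.3-fold higher number from compound 1 to compound 2 (0.11 log units; within the scatter), a 1.8-fold lower number from compound 1 to compound 3 (0.24 log units; within the scatter), a 2.3-fold lower number from compound 2 to compound 3 (0.35 log units; beyond the scatter). None of them introduces a hydrogen-bond donor, so the bearing is indirect. A small step is expected, a 1.7-fold higher number from compound 3 to compound 4 (0.22 log units; within the scatter), with wide uncertainty. Compound 4 is therefore estimated at 2000 nM, within 700 nM to 6000 nM.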

Compound 4, half-maximal inhibitory concentration: 8100 nM
Compound 4: the middle estimate sits 4.1-fold (0.61 log units) below what was measured; the measured number lies above the stated range.
By their numbers in this assay, from the lowest: compounds 3, 1 and 2 (each within the scatter of the next, the first and the last beyond it); then compound 4.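

Hexylamino on the sulfonyl sulfur has the same count of heavy atoms as butyl(ethyl)amino but adds a hydrogen-bond donor, and in this assay it gives larger steps than any among the earlier compounds (a 6.8-fold higher number from compound 3 to compound 4 (0.83 log units; beyond the scatter); a 3.0-fold higher number from compound 2 to compound 4 (0.48 log units; beyond the scatter); a 3.9-fold higher number from compound 1 to compound 4 (0.59 log units; beyond the scatter)). This position is therefore less tolerant of change than the earlier compounds suggested, and the data give no measured cause. On these data alone, whether the hydrogen on the nitrogen or the single long chain matters stays open. Butylamino, which keeps that hydrogen on a shorter chain, and methyl(pentyl)amino, which has two chains and no such hydrogen, would help separate the two.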